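This account rests on a few compounds, and the source may have more. Where it says the series, first, only, none or still open, it means among the compounds named here.

Of the compounds shown here, three of one shared core have been measured in a functional assay on cells (Cancer cell lines, Homo sapiens) for cytotoxicity, read by sulforhodamine B assay, with a stated time of 48 h; a lower number here means a stronger inhibitor of growth, a higher number a weaker inhibitor of growth. Compound 1 `O=C1N=C(N2N=C(c3ccccc3)CC2c2ccccc2O)S/C1=C1/C(=O)Nc2ccccc21` gives 2070 nM. Compound 2 `COc1ccc(C2CC(c3ccccc3)=NN2C2=NC(=O)/C(=C3\C(=O)Nc4ccccc43)S2)cc1` gives 2010 nM, and compound 3 `COc1ccc(C2=NN(C3=NC(=O)/C(=C4\C(=O)Nc5ccccc54)S3)C(c3ccc(OC)cc3)C2)cc1` gives 85200 nM. Compound 2 shows the lowest number of the three, though its step to compound 1, a 1.0-fold lower number from compound 1 to compound 2 (0.01 log units; within the scatter), stays within the scatter, so the two cannot be ranked; only compound 3 stands clearly apart, through a 42-fold higher number from compound 2 to compound 3 (1.63 log units; beyond the scatter).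

Compound 4 `CN(C)c1ccc(C2CC(c3ccccc3)=NN2C2=NC(=O)/C(=C3\C(=O)Nc4ccccc43)S2)cc1` has not yet been measured. It differs from compound 2 in one place: dimethylamino in place of methoxy on an aromatic carbon. Within the data shown here, no measured step swaps one group for another at this same aromatic carbon. The step from compound 1 to compound 2 changed a group on a saturated ring carbon and moved nothing beyond the scatter, while the step from compound 2 to compound 3 added a methoxy on a different aromatic ring and cost a great deal. Neither is a direct guide, so the expectation for compound 4 is a step of a 1.5-fold higher number from compound 2 to compound 4 (0.17 log units; within the scatter), with wide uncertainty. Compound 4 is therefore estimated at 3000 nM, in a range from 700 nM to 13000 nM.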

Compound 4, concentration for 50% growth inhibition: 6370 nM
Compound 4: middle estimate off by 2.1-fold (0.33 log units), on the low side; measured number inside the range.
By their numbers in this assay, from the lowest: compounds 2 and 1 (each within the scatter of the next); then compound 4; then compound 3.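

Among these compounds, at this aromatic carbon, para to a large group, the earlier compounds showed no swap of one group for another; in this assay the first such swap, 4-methoxyphenyl to 4-(dimethylamino)phenyl, gives a modest but real shift (a 3.2-fold higher number from compound 2 to compound 4 (0.50 log units; beyond the scatter)), so what sits here does matter. Replacing the 2-hydroxyphenyl group on the saturated ring carbon with 4-(dimethylamino)phenyl also gives a shift beyond the scatter (a 3.1-fold higher number from compound 1 to compound 4 (0.49 log units; beyond the scatter)), although 4-methoxyphenyl at that carbon gave none, so the outcome there depends on the group chosen. No measurement available here explains why dimethylamino gives the higher number.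

Going by these compounds, whether a plain amino group or a carboxylic acid at the aromatic carbon would give a lower number than compound 2 remains open. So does whether the methoxy-to-dimethylamino swap would have the same effect with the added methoxy of compound 3 present.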